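Swapping a Chlorophenyl for Cyclohexyl in Amide Inhibitors

The source may report more compounds than this note shows. Statements on the series, on what has been measured and on what is new or still open speak of the compounds shown alone.

Two compounds have been measured in an assay on HEK293 cells for inhibition of N-acylethanolamine-hydrolyzing acid amidase (Rattus norvegicus), read by LC-MS, with a stated time of 30 min; on this read-out higher numbers stand for weaker inhibition and lower numbers for stronger inhibition:

compound 1 `O=C(CCc1ccc(-c2ccccc2F)cc1)N1CCCC1` gives 2800 nM
compound 2 `O=C(CCc1ccc(-c2cccc(Cl)c2)cc1)N1CCCC1` gives 25400 nM

Compound 2 stands at the highest of the two numbers, meaning the weaker inhibition of the pair; its nearest neighbour is compound 1, and the step from one to the other is a 9.1-fold higher number from compound 1 to compound 2 (0.96 log units; beyond the scatter). Both compounds share the same core, and differ only in the group attached to an aromatic carbon of that core.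

The next compound, compound 3 `O=C(CCc1ccc(C2CCCCC2)cc1)N1CCCC1`, has not yet been measured in this assay. It is derived from compound 2 by the change (cyclohexyl in place of 3-chlorophenyl on an aromatic carbon). Among the measured compounds shown here, the only measured step that bears on this position is the one from compound 1 to compound 2, and it shows that exchanging one group at this position for another can move the number by a modest but real amount. For the measured compounds named here, no measured compound carries a non-aromatic ring here, so the direction of the change is uncertain. Compound 3 is expected to give 10000 nM, within a range of 2500 nM to 40000 nM, a step of a 2.5-fold lower number from compound 2 to compound 3 (0.40 log units; beyond the scatter) that is an estimate only.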

Compound 3, half-maximal inhibitory concentration: 500 nM
The estimate for compound 3 lay 20-fold (1.30 log units) above the measured number; the measured number lies below the stated range.
By their numbers in this assay, from the lowest: compound 3; then compound 1; then compound 2.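

In this assay, replacing the aromatic ring with a non-aromatic one moves the number strongly downward: cyclohexyl in place of 3-chlorophenyl gives a 51-fold lower number from compound 2 to compound 3 (1.71 log units; beyond the scatter) and cyclohexyl in place of 2-fluorophenyl gives a 5.6-fold lower number from compound 1 to compound 3 (0.75 log units; beyond the scatter). This position therefore does not require an aromatic ring for inhibition, and among these three compounds, the one with a six-membered non-aromatic ring of carbon only, compound 3, is the strongest inhibitor, while both compounds with a halogen-bearing phenyl ring give higher numbers. Nothing available here explains why the cyclohexyl group does better, so the result stands as an observation only.

The compounds shown leave open how a plain phenyl ring with no halogen would compare, so the effect of the ring type cannot yet be separated from that of the chlorine or fluorine atom. Going by these compounds, it also remains open whether the gain would hold for a smaller cyclopentyl ring, a piperidine ring containing nitrogen, or an open hexyl chain at the same position.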